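The source may report more compounds than this note shows. Statements on the series, on what has been measured and on what is new or still open speak of the compounds shown alone.

Compound 1, `COc1ccc(-c2cnc3nc(N)nc(N4CCC(C)CC4)c3n2)cc1OC`: 800 nM
Compound 2, `CC(C)Oc1nc(N)nc2ncc(-c3ccc(F)c(F)c3)nc12`: 10000 nM
Compound 3, `CCOc1nc(N)nc2ncc(-c3cccc(OC)c3)nc12`: 8300 nM

All three compounds were tested in a functional assay on cells (T-cell, Homo sapiens) for inhibition; a lower number here means a stronger inhibitor, a higher number a weaker inhibitor. Compound 1 gives the lowest number of the three, 800 nM. Its nearest neighbour is compound 3 with 8300 nM, a gap beyond the usual scatter, and the furthest is compound 2 with 10000 nM, also beyond the scatter. Compounds 2 and 3 share neither the aryl group nor the substituent on the shared core with compound 1, so their values do not isolate any single change.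

Compound 4, `COc1ccc(-c2cnc3nc(N)nc(NC4CCCC4)c3n2)cc1OC`, has not yet been measured in this assay. It differs from compound 1 in one place: cyclopentylamino in place of 4-methylpiperidin-1-yl on an aromatic carbon. Among the measured compounds shown here, no pair of measured compounds shows this change by itself, so its size can only be guessed. A ring of similar size still sits at that place, and the data give no reason to expect a large shift in either direction. The step of a 1.9-fold higher number from compound 1 to compound 4 (0.27 log units; within the scatter) is expected to be small, not clearly beyond the scatter. In this assay compound 4 is estimated to give 1500 nM, with a range from 400 nM to 6000 nM.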

Compound 4, half-maximal inhibitory concentration: 800 nM
The estimate for compound 4 lay 1.9-fold (0.27 log units) above the measured number; the range from low to high includes it.
By their numbers in this assay, from the lowest: compounds 1 and 4 (each within the scatter of the next); then compounds 3 and 2 (each within the scatter of the next).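

In this assay, the replacement of 4-methylpiperidin-1-yl by cyclopentylamino on this aromatic carbon of the shared core gives no change at the digits printed from compound 1 to compound 4 (within the scatter). Among the compounds shown here, this is the first single-place comparison, and it shows that this position can go from a six-membered ring with one hetero atom and no hydrogen-bond donor to a five-membered ring of carbon only with one hydrogen-bond donor without any shift beyond the scatter. Nothing available here explains why the two numbers coincide.

The step changes the ring size, the ring hetero atom and the donor count together, so it cannot say whether each has no effect alone or whether their effects offset one another; cyclohexylamino or plain piperidin-1-yl at this place would begin to separate them. Morpholine, piperazine and open-chain amines such as diethylamino also remain untested among the compounds shown, and the steps to compound 2 and compound 3 cannot be read, since both differ from compound 1 and compound 4 in more than one place.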